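Methoxy to hydroxy in a small cytotoxic series

This account rests on a few compounds, and the source may have more. Where it says the series, first, only, none or still open, it means among the compounds named here.

Values in a functional assay on HCT-116 cells (Homo sapiens) for cytotoxicity, read by scintillation counting and thymidine incorporation, with a stated time of 72 h; on this read-out higher numbers stand for weaker inhibition and lower numbers for stronger inhibition
compound 1 `COc1cc(OC)cc(C(=Cc2ccccc2)c2ccc(OC)c(O)c2)c1`: > 10000 nM
compound 2 `CC=C(c1cc(OC)cc(OC)c1)c1ccc(OC)c(O)c1`: 30 nM
compound 3 `C=C(c1cc(OC)cc(OC)c1)c1ccc(OC)c(OC)c1`: > 10000 nM
compound 4 `C=C(c1cc(OC)cc(OC)c1)c1ccc(OC)c(O)c1`: not yet measured

Compound 3 gives > 10000 nM in this assay, which is a limit and not a number. The change to examine is hydrogen in place of methyl on an oxygen on an aromatic ring, or methoxy to hydroxy. Within the data shown here, no measured step covers this change directly. Among the measured compounds shown here, the only measured step, an at least 330-fold lower number from compound 1 to compound 2 (2.52 log units; beyond the scatter), is a different change, methyl in place of phenyl on a chain carbon, and it bears on the question only indirectly. It does show how far a single change can move values in this set.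

Compound 2 carries the hydroxy and gives 30 nM, and this value is the main ground for expecting a lower number for compound 4, whose chain likewise carries no phenyl. Compound 1 goes against any simple reading, since it also carries the hydroxy and still sits at a limit. A large step towards stronger inhibition is therefore expected, although a result at the limit remains possible.

The expected change is an at least 100-fold lower number from compound 3 to compound 4 (2.00 log units; beyond the scatter) in this assay, and this is an estimate only.

For compound 4 the estimated value is 100 nM, with an expected range from 10 nM to 3000 nM.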

Compound 4, half-maximal inhibitory concentration: 21 nM
Compound 4: the middle estimate sits 4.8-fold (0.68 log units) above what was measured; the range from low to high includes it.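

In this assay, among these compounds, the hydroxy on the aromatic ring now stands alone as the changed group, and hydrogen in place of methyl on that oxygen gives an at least 470-fold lower number from compound 3 to compound 4 (2.67 log units; beyond the scatter) as a large step that no earlier pair isolated. On the double-bonded chain carbon, hydrogen in place of methyl gives a 1.4-fold lower number from compound 2 to compound 4 (0.15 log units; within the scatter) with no separation beyond the scatter, so the hydroxy goes with strong inhibition whether that carbon carries hydrogen or methyl. Hydrogen in place of phenyl on the same carbon gives an at least 470-fold lower number from compound 1 to compound 4 (2.67 log units; beyond the scatter) with the hydroxy unchanged, which means the hydroxy is not enough on its own and the phenyl compound goes against any rule built on the hydroxy alone.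

Still open, going by these compounds, is what an amine in place of the hydroxy, or a longer chain such as ethyl on the double-bonded chain carbon, would give on this read-out. The true size of the two large steps also stays open, as each starts from a value that is a limit and not a number: the limit of > 10000 nM in this assay, at which 2 of the 4 values shown sit.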